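Notes on a benzyl halogen swap and cytotoxicity

The compounds below may be only part of what the source reports. "The series", "measured", "known", "first", "only" and "open" are said of these compounds alone.

Compound 1 `COC(=O)c1ccc(NCc2cncn2Cc2ccccc2Cl)cc1-c1ccccc1` is the reference point of this small set. Going by the values given here, in a toxicity assay on NIH3T3 cells (Mus musculus) for cytotoxicity, read by resazurin assay (a lower number here means that less compound is needed, a higher number that more compound is needed for the effect), compound 1 gives 10000 nM, the only numerical value in hand. Compound 2 `O=C(OC1CCCCC1)c1ccc(NCc2cncn2Cc2ccc(-c3ccccc3)cc2)cc1-c1ccccc1` reaches only > 10000 nM in this assay, which is a limit of the assay rather than a number. Compound 1 therefore cannot be ranked against compound 2 (the limit of > 10000 nM in this assay, at which 1 of the 2 values shown sits). Among the compounds with values here, no step between two measured compounds is available, so the size of any structural effect in this assay has not been measured here.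

Compound 3 `COC(=O)c1ccc(NCc2cncn2Cc2ccc(Br)cc2)cc1-c1ccccc1` remains to be tested in this assay. It differs from compound 1 by 4-bromophenyl in place of 2-chlorophenyl on a saturated chain carbon bound to an aromatic nitrogen. The exchange of one halogen-bearing benzyl for another is expected to produce no step beyond the usual scatter, in either direction. The expected step is no change at the digits printed from compound 1 to compound 3 (within the scatter). Compound 3 is accordingly estimated at 10000 nM in this assay, with a range from 5000 nM to 20000 nM, and a limit reading would not be surprising.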

Compound 3, half-maximal effective concentration: > 10000 nM
Compound 3: only a limit was reported (the forecaster's own chance of this, stated with the estimate: 40%); the middle value lies on the limit itself.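

Going by these compounds alone, the first step at this place, on a saturated chain carbon bound to an aromatic nitrogen, is now available: exchanging 2-chlorobenzyl for 4-bromobenzyl on the core of compound 1 gives, in this assay, a number no lower from compound 1 to compound 3 (the limit leaves the size open). This change of benzyl group therefore brings no drop in the number, so less compound is not needed for the effect. Its size stays unreadable, and the series now rests mostly on one ceiling: the limit of > 10000 nM in this assay, at which 2 of the 3 values shown sit.

The compounds shown leave open whether the halogen or its ring placement matters, since 2-bromobenzyl and 4-chlorobenzyl would separate the two. Also open, as far as these compounds go, is how a benzyl group carrying a primary amine or a carboxylic acid would read at this place in this assay.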